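Swapping the urea aryl: fluoro for chloro

A few compounds are considered here, and "the series" means these few. Any claim that something is new, unique, unknown or untested is made for them only; others in the source may bear on it.

For the measured compounds named here, compound 3 `CCN(CC)CCCNc1nc(-c2ccc(NC(=O)Nc3ccc(F)cc3)cc2)nc2c(Cl)c(Cl)sc12` gives 350 nM in a functional assay on HT-29 cells (Homo sapiens) for cytotoxicity, read by MTT assay, with a stated time of 72 h (a higher number here means a weaker inhibitor, a lower number a stronger inhibitor), the lowest of the three numbers measured so far. Compound 1 `CN(C)CCCNc1nc(-c2ccc(NC(=O)Nc3ccccc3Cl)cc2)nc2c(Cl)c(Cl)sc12` gives 820 nM in this assay, and compound 2 `CCN(CC)CCCNc1nc(-c2ccc(NC(=O)Nc3ccccc3)cc2)nc2c(Cl)c(Cl)sc12` gives 820 nM. Going by the values given here, the only single-point step among them is a 2.3-fold lower number from compound 2 to compound 3 (0.37 log units; beyond the scatter). Compound 4 `CCN(CC)CCCNc1nc(-c2ccc(NC(=O)Nc3ccccc3Cl)cc2)nc2c(Cl)c(Cl)sc12` differs from compound 3 by 2-chlorophenyl in place of 4-fluorophenyl on an amide-type nitrogen. Among the compounds with values here, no measured step covers this exact change; compound 1 already carries the 2-chlorophenyl group, and its number sits with that of compound 2, which bears the plain phenyl, so the gain seen for the 4-fluorophenyl in compound 3 is not expected to carry over. The number for compound 4 is therefore expected to rise, a 2.1-fold higher number from compound 3 to compound 4 (0.33 log units; beyond the scatter). Compound 4 is estimated at 750 nM, within a range from 350 nM to 1600 nM.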

Compound 4, half-maximal inhibitory concentration: 410 nM
Beside the measured number, compound 4's estimate is 1.8-fold (0.26 log units) above it; low and high end bracket the measured number.
By their numbers in this assay, from the lowest: compounds 3, 4, 1 and 2 (each within the scatter of the next, the first and the last beyond it).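

On this amide-type nitrogen, 2-chlorophenyl and 4-fluorophenyl cannot be told apart in this assay, with a 1.2-fold higher number from compound 3 to compound 4 (0.07 log units; within the scatter) as the step between them. Adding a chloro to the phenyl group gives a 2.0-fold lower number from compound 2 to compound 4 (0.30 log units; within the scatter) and diethylamino in place of dimethylamino gives a 2.0-fold lower number from compound 1 to compound 4 (0.30 log units; within the scatter) so neither single change separates its pair beyond the scatter. No measurement is available to account for these results. From the compounds shown here alone, what a pyridyl group on the amide-type nitrogen, or a morpholine in place of diethylamino on the saturated chain, would give remains open.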